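Oxan-4-yl for Cyclohexyl: An Expected Half-Life

The source may hold more compounds than are shown below. What is called first, only, known or untested is meant among the compounds shown, and "the series" means these compounds.

Measured compounds:
compound 1 `O=C(C1CCCCC1)N1N=CCC1c1ccccc1`, 0.617 h
compound 2 `CC(C)(C)C(=O)N1CCSC1c1ccccc1`, 0.3 h

In an ADME assay on microsomes (Homo sapiens) for metabolic stability (a lower number here means that the compound disappears faster, a higher number that the compound lasts longer), compound 1 gives 0.617 h, the highest of the two numbers recorded. The nearest number belongs to compound 2, which in this assay gives 0.3 h; the gap between these two values lies beyond the scatter. Among the compounds with values here, no pair of measured compounds differs in only one place, so no single step has yet been characterised.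

Compound 3 `O=C(C1CCOCC1)N1N=CCC1c1ccccc1` is not yet measured in this assay. It differs from compound 1 in one place: oxan-4-yl in place of cyclohexyl on a carbonyl carbon. Within the data shown here, with no measured step of this kind to lean on, the size of the change is uncertain; the step from compound 1 to compound 3 is expected to be modest, at most a small rise, and may well fall within the scatter, a 1.3-fold higher number from compound 1 to compound 3 (0.11 log units; within the scatter). For compound 3 the estimate in this assay is 0.8 h, with a range from 0.35 h to 1.8 h.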

Compound 3, half-life: > 1.5 h
Compound 3 gave a limit, no number (the forecaster's own chance of this, stated with the estimate: 5%); middle value at least 1.8-fold (0.27 log units) from the limit.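

Oxan-4-yl in place of cyclohexyl on a carbonyl carbon is the first single change in this set that can be read, and in this assay it gives an at least 2.4-fold higher number from compound 1 to compound 3 (0.38 log units; beyond the scatter). This position therefore responds to the exchange of one ring carbon for oxygen, with the size of the group left the same, and the step lies beyond the scatter. The result for compound 3 is a limit of the assay and not a number, so the step has a lower bound but no upper one: the limit of > 1.5 h in this assay, at which 1 of the 3 values shown sits.

The compounds shown leave open how far the half-life of compound 3 extends past that limit, and whether an amine such as piperidin-4-yl on the same carbonyl carbon would give a similar step. They also do not tell whether oxan-4-yl would give such a step on the core of compound 2.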